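The source may hold more compounds than are shown below. What is called first, only, known or untested is meant among the compounds shown, and "the series" means these compounds.

Measured so far in a functional assay on PC-3 cells (Homo sapiens) for inhibition, read by MTT assay, with a stated time of 48 h; on this read-out lower numbers stand for stronger inhibition and higher numbers for weaker inhibition:
Compound 1 `COc1ccc(-n2c(S)nnc2-c2cc(OC)c(OC)c(OC)c2)cc1`: > 60000 nM (a limit)
Compound 2 `COc1ccc(NC(=O)CSc2nnc(-c3cc(OC)c(OC)c(OC)c3)n2-c2ccc(OC)cc2)cc1`: 25800 nM
Compound 3 `COc1cc(-c2nnc(S)n2-c2ccc(N(C)C)cc2)cc(OC)c1OC`: > 60000 nM (a limit)

Compound 3 has no exact number, only the limit > 60000 nM. This is the limit of > 60000 nM in this assay, at which 2 of the 3 values shown sit. Compound 4 `COc1cc(-c2nnc(SCc3ccccc3)n2-c2ccc(N(C)C)cc2)cc(OC)c1OC` is made from it by one change, benzyl in place of hydrogen on a sulfur.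

Two measured steps might bear on this. The step that the two limits leave unreadable from compound 1 to compound 3 gives no size that can be carried over. The more useful one changes the same sulfur: an at least 2.3-fold lower number from compound 1 to compound 2 (0.36 log units; beyond the scatter), with ((4-methoxyphenyl)carbamoyl)methyl in place of hydrogen on a sulfur. That is a single example with a different group entering, so it is only a rough guide. Still, it points to a modest move towards lower numbers in this assay, and compound 4 is expected to behave similarly. The expected change is an at least 2.0-fold lower number from compound 3 to compound 4 (0.30 log units; that floor lies within the scatter). A reported limit would also be no surprise.

For compound 4 the estimated value is 30000 nM, with an expected range from 9000 nM to 70000 nM.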

Compound 4, half-maximal inhibitory concentration: 55800 nM
For compound 4 the middle estimate is 1.9-fold (0.27 log units) below the measured one; the range from low to high includes it.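

In this assay, benzyl on the sulfur gives an at least 1.0-fold lower number from compound 3 to compound 4 (0.03 log units; that floor lies within the scatter), and that floor alone does not establish a real gain. Even so, both compounds shown with a group on this sulfur, compound 2 and compound 4, have exact values, whereas both with hydrogen there, compound 1 and compound 3, stop at a limit, and this now holds with either the methoxy or the dimethylamino group on the aromatic ring. The true size of the step stays unknown because the starting point is only a limit: the limit of > 60000 nM in this assay, at which 2 of the 4 values shown sit.

Compound 2 and compound 4 differ in more than one place, so their two sulfur groups cannot be ranked against each other. The compounds shown also leave open how a small methyl, or a chain ending in an amine or a carboxylic acid, would read on this sulfur.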